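The compounds below may be only part of what the source reports. "The series", "measured", "known", "first", "only" and "open" are said of these compounds alone.

Measured in a functional assay on PC-3 cells (Homo sapiens) for inhibition, read by MTT assay, with a stated time of 72 h; on this read-out lower numbers stand for stronger inhibition and higher numbers for weaker inhibition:
- compound 1, `O=C(CSc1nc(Nc2ccccc2)c2ccccc2n1)Nc1ccccc1Br`: 19800 nM
- compound 2, `O=C(CSc1nc(Nc2ccccc2)c2ccccc2n1)Nc1cccc(F)c1`: 15600 nM

Compound 2 stands next to compound 1 only, and the step of a 1.3-fold lower number from compound 1 to compound 2 (0.10 log units; within the scatter) places the two values within the scatter of each other, so no order can be read between them.

The next compound, compound 3, `O=C(CSc1nc(Nc2ccccc2)c2ccccc2n1)Nc1cccc(Br)c1`, differs from compound 2 by bromo in place of fluoro on an aromatic carbon, the bromo sitting on an aromatic carbon of a six-membered aromatic ring of carbon only, meta to a large group. Among the measured compounds shown here, no measured step shows this exchange: the one step in hand, a 1.3-fold lower number from compound 1 to compound 2 (0.10 log units; within the scatter), changes both the halogen and its position at once and was within the scatter. The data therefore give no direction for this assay; the expectation is a change no larger than the scatter.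

For compound 3 the expected value in this assay is 15000 nM, with a range of 6000 nM to 40000 nM, which means an expected step of a 1.0-fold lower number from compound 2 to compound 3 (0.02 log units; within the scatter).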

Compound 3, half-maximal inhibitory concentration: 11400 nM
Compound 3: middle estimate off by 1.3-fold (0.12 log units), on the high side, and the stated range covers the measured number.
By their numbers in this assay, from the lowest: compounds 3, 2 and 1 (each within the scatter of the next).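

In this assay, bromo in place of fluoro on an aromatic carbon, meta to a large group, is now read directly: a 1.4-fold lower number from compound 2 to compound 3 (0.14 log units; within the scatter), so the two halogens are not separated at this place. 3-bromophenyl in place of 2-bromophenyl on the amide-type nitrogen keeps the halogen the same and alters only its place, and a 1.7-fold lower number from compound 1 to compound 3 (0.24 log units; within the scatter) shows that this change does not separate the two compounds either. No supporting evidence bears on these results.

The three compounds shown carry only fluoro or bromo on this ring, so a step beyond the scatter remains to be found. An amine, a carboxylic acid or a methoxy group on this ring could test whether this position responds to anything other than a halogen.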